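The source may report more compounds than this note shows. Statements on the series, on what has been measured and on what is new or still open speak of the compounds shown alone.

Compound 2 `CC(C)=CCOc1ccc(C(=O)/C=C/c2cccnc2)c(O)c1` gives the highest of the three numbers in an ADME assay on THP-1 cells (Homo sapiens) for cytotoxicity, read by resazurin assay, with a stated time of 72 h (on this read-out higher numbers stand for lower toxicity in this test and lower numbers for higher toxicity in this test), at 100000 nM. Compound 1 `CC(C)=CCOc1ccc(C(=O)/C=C/c2ccncc2)c(O)c1` gives 16000 nM in this assay, and compound 3 `COc1cc(OCC=C(C)C)ccc1C(=O)/C=C/c1cccnc1` gives 40000 nM. Two steps were measured among these: a 6.3-fold higher number from compound 1 to compound 2 (0.80 log units; beyond the scatter) and a 2.5-fold lower number from compound 2 to compound 3 (0.40 log units; beyond the scatter). Compound 4 `C#CCOc1ccc(C(=O)/C=C/c2cccnc2)c(O)c1` has not yet been measured. It differs from compound 2 in one place: ethynyl in place of 2-methylprop-1-en-1-yl on a saturated chain carbon bound to an oxygen on an aromatic ring. Neither measured step bears on this change. The step from compound 1 to compound 2 alters the ring on the double-bonded chain, and the step from compound 2 to compound 3 alters the hydrogen on an oxygen on the aromatic ring, while the 3-methylbut-2-en-1-yl chain on the other oxygen is the same in all three measured compounds. Among the measured compounds shown here, with no step touching that chain, the step expected from compound 2 to compound 4 is a 1.4-fold lower number from compound 2 to compound 4 (0.15 log units; within the scatter), that is, none beyond the scatter, with the direction open. Compound 4 is therefore estimated at 70000 nM, with a range from 25000 nM to 150000 nM.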

Compound 4, half-maximal cytotoxic concentration: 25000 nM
Compound 4: middle estimate off by 2.8-fold (0.45 log units), on the high side, within the range that was stated.
By their numbers in this assay, from the lowest: compounds 1, 4 and 3 (each within the scatter of the next, the first and the last beyond it); then compound 2.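

Among the compounds shown here, the chain on this oxygen, the same in all the earlier compounds, proves not to be neutral in this assay: exchanging 3-methylbut-2-en-1-yl for propargyl gives a 4.0-fold lower number from compound 2 to compound 4 (0.60 log units; beyond the scatter). The change thus moves the number in the direction of higher toxicity in this test, and compound 2 keeps the highest number of the four, with its steps to the other three all beyond the scatter. Nothing available explains this step.

The compounds shown leave open whether the step goes with the smaller group or with the triple bond, a question that a propyl group on the same oxygen would address. They also leave open whether the same exchange would have a similar effect with the pyridin-4-yl group of compound 1 or the methyl on the other oxygen of compound 3.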